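Replacing the Methoxyphenyl Group: An Expected Cytotoxicity Step

The source may hold more compounds than are shown below. What is called first, only, known or untested is meant among the compounds shown, and "the series" means these compounds.

Compound 1 `Cc1ccc(-c2nnc(SCCn3c([N+](=O)[O-])cnc3C)o2)cc1`: 12500 nM
Compound 2 `COc1ccc(-c2nnc(SCCn3c([N+](=O)[O-])cnc3C)o2)cc1`: 10200 nM
Compound 3 `Cc1ncc([N+](=O)[O-])n1CCSc1nnc(-c2cccnc2)o1`: 31600 nM

In a functional assay on SGC-7901 cells (Homo sapiens) for cytotoxicity, read by MTT assay, with a stated time of 48 h (a higher number here means a weaker inhibitor, a lower number a stronger inhibitor), compound 2 gives the lowest of the three numbers, though its gap to compound 1, a 1.2-fold lower number from compound 1 to compound 2 (0.09 log units; within the scatter), lies within the scatter. Compound 4 `Cc1ncc([N+](=O)[O-])n1CCSc1nnc(-c2ccnc(Cl)c2)o1` differs from compound 2 by 2-chloropyridin-4-yl in place of 4-methoxyphenyl on an aromatic carbon. Within the data shown here, two measured steps bear on this change, both putting pyridin-3-yl in place of a carbon-only aromatic ring: a 2.5-fold higher number from compound 1 to compound 3 (0.40 log units; beyond the scatter) and a 3.1-fold higher number from compound 2 to compound 3 (0.49 log units; beyond the scatter), each a modest weakening beyond the scatter. The chlorine on the entering ring has no measured precedent among these compounds. Compound 4 is therefore expected to move in the same direction, a 2.5-fold higher number from compound 2 to compound 4 (0.39 log units; beyond the scatter), with an estimated 25000 nM and a range from 12000 nM to 55000 nM.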

Compound 4, half-maximal inhibitory concentration: 32300 nM
Compound 4: middle estimate off by 1.3-fold (0.11 log units), on the low side, and the stated range covers the measured number.
By their numbers in this assay, from the lowest: compounds 2 and 1 (each within the scatter of the next); then compounds 3 and 4 (each within the scatter of the next).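

In this assay, exchanging pyridin-3-yl for 2-chloropyridin-4-yl gives numbers that cannot be told apart (a 1.0-fold higher number from compound 3 to compound 4 (0.01 log units; within the scatter)), so this chlorine-bearing ring sits with the pyridin-3-yl ring. The weakening against carbon-only rings now appears with a second nitrogen-containing ring (a 3.2-fold higher number from compound 2 to compound 4 (0.50 log units; beyond the scatter); a 2.6-fold higher number from compound 1 to compound 4 (0.41 log units; beyond the scatter)). Nothing available here explains these differences. From the compounds shown here alone, the separate contributions of the chlorine and of the ring nitrogen's place remain open, since both differ between compound 3 and compound 4. Going by these compounds, how an amine or a carboxylic acid on this aromatic ring would behave also remains open.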